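A few compounds are considered here, and "the series" means these few. Any claim that something is new, unique, unknown or untested is made for them only; others in the source may bear on it.

Measured compounds in an ADME assay on Raji cells (Homo sapiens) for cytotoxicity, with a stated time of 72 h; a lower number here means that less compound is needed, a higher number that more compound is needed for the effect:

compound 1, `Cc1cc(NC(=O)Nc2cc(F)ccc2F)c2ccccc2n1`: > 25000 nM
compound 2, `Cc1cc(NC(=O)Nc2ccc(N)cc2)c2ccccc2n1`: > 25000 nM
compound 3, `COC(=O)c1cccc(NC(=O)Nc2cc(C)nc3ccccc23)c1`: 26000 nM

Compound 2 gives only a limit of the assay in this assay, > 25000 nM, not a number. Compound 1 also returns a limit, > 25000 nM. Compound 3 gives a number, 26000 nM. Going by the values given here, two of the three values sit at the limit of > 25000 nM in this assay, at which 2 of the 3 values shown sit, so compound 2 stands where most of the series stands, with no measured steps to compare.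

Compound 4, `Cc1cc(NC(=O)Nc2ccc(Cl)cc2)c2ccccc2n1`, differs from compound 2 in one place: chloro in place of amino on an aromatic carbon. Among the compounds with values here, with no measured step to lean on, the expected step from compound 2 to compound 4 is a step that the limit leaves unreadable from compound 2 to compound 4, which is no change beyond the usual scatter. Compound 4 is therefore estimated at 30000 nM, within a range of 15000 nM to 60000 nM, most likely reported again as a limit.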

Compound 4, half-maximal effective concentration: > 25000 nM
Compound 4 gave a limit, no number; the forecaster's own chance of this, stated with the estimate: 75%; the middle value does not contradict the limit.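

Compound 2 and compound 4 each give only a limit of the assay, not a number, so no step between them can be read: the limit of > 25000 nM in this assay, at which 3 of the 4 values shown sit.

In this assay the compounds shown leave open whether chloro in place of amino on an aromatic carbon changes the concentration needed at all.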